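Ester chain extension on the methyl analogue

A few compounds are considered here, and "the series" means these few. Any claim that something is new, unique, unknown or untested is made for them only; others in the source may bear on it.

Compound 1 `CCCCc1nc(C(C)C)c(CC(=O)OC)c(=O)n1Cc1ccc(-c2ccccc2-c2noc(=O)[nH]2)cc1` gives 10.5% in an ADME assay on microsomes from liver (Homo sapiens) for metabolic stability, with a stated time of 30 min; on this read-out higher numbers stand for a more stable compound and lower numbers for a less stable compound. Among the compounds with values here, compound 2 `CC#CCOC(=O)Cc1c(C(C)C)nc(CCCC)n(Cc2ccc(-c3ccccc3-c3noc(=O)[nH]3)cc2)c1=O` gives 13.7% in this assay, and the step of a number 3.2 percentage points higher from compound 1 to compound 2 (within the scatter) is the only measured change at the ester chain. Within the data shown here, compound 3 `CCCCc1nc(C)c(CC(=O)OC)c(=O)n1Cc1ccc(-c2ccccc2-c2noc(=O)[nH]2)cc1` gives 69.6% in this assay; the step of a number 59.1 percentage points higher from compound 1 to compound 3 (beyond the scatter) is the one large change in the set. Compound 3 thus holds the highest number of the three, beyond the scatter from both compound 2 and compound 1.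

Compound 4 `CCCCc1nc(C)c(CC(=O)OCC(C)C)c(=O)n1Cc1ccc(-c2ccccc2-c2noc(=O)[nH]2)cc1` differs from compound 3 in one place: isopropyl in place of hydrogen on a saturated chain carbon bound to an oxygen next to a carbonyl group. Among the measured compounds shown here, the one measured step bearing on this change is a number 3.2 percentage points higher from compound 1 to compound 2 (within the scatter), which stayed within the scatter while the ester chain grew at the same place; the present change likewise grows the chain and keeps the methyl on the aromatic carbon that marks compound 3. No step beyond the scatter is therefore expected in this assay, at most a shift of the size seen in a number 3.2 percentage points higher from compound 1 to compound 2 (within the scatter). Compound 4 is expected to give 68% in this assay, within a range from 50% to 85%. The expected step is a number 1.6 percentage points lower from compound 3 to compound 4 (within the scatter).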

Compound 4, percent of the compound remaining: 2.4%
The estimate for compound 4 lay 65.6 percentage points above the measured number; the measured number lies below the stated range.
By their numbers in this assay, from the lowest: compounds 4, 1 and 2 (each within the scatter of the next, the first and the last beyond it); then compound 3.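

Working notes: in this assay the step of a number 67.2 percentage points lower from compound 3 to compound 4 (beyond the scatter) shows that, with methyl on the aromatic carbon, the ester chain is a place where the change from methoxycarbonyl to isobutoxycarbonyl carries a large effect on the read-out. The earlier step of a number 3.2 percentage points higher from compound 1 to compound 2 (within the scatter) could not show this: it was read with isopropyl on the aromatic carbon, where compound 1 already gives 10.5% and so sits low on the scale before any change at the ester chain. No measured finding is available that accounts for the drop at compound 4.

The compounds shown leave open whether the result follows the branching of isobutyl or the length of the chain, which an unbranched n-butyl ester, an ethyl ester or the prop-1-yn-1-yl extended ester of compound 2 carried onto the methyl analogue would help separate. Also open, on these data alone, is how a free carboxylic acid or an amide at this place would read, and whether ethyl on the aromatic carbon would keep the number seen with methyl.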